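Replacing methoxy with dimethylamino in compound 2

The source may report more compounds than this note shows. Statements on the series, on what has been measured and on what is new or still open speak of the compounds shown alone.

Compound 1 `COc1cc(/C=C/c2ccc3ccccc3c2)cc([N+](=O)[O-])c1OC` gives > 10000 nM as a limit in a functional assay on HL-60 cells (Homo sapiens) for inhibition (a lower number here means a stronger inhibitor, a higher number a weaker inhibitor), and no exact number.
Compound 2 `COc1c([N+](=O)[O-])cc(/C=C/c2ccc3ccccc3c2)cc1[N+](=O)[O-]` gives > 5000 nM as a limit in this assay and no exact number.
Compound 3 `COc1c([N+](=O)[O-])cc(/C=C\c2ccc3ccccc3c2)cc1[N+](=O)[O-]` gives > 5000 nM as a limit in this assay and no exact number.

Compound 2 has only the limit > 5000 nM and no exact number. The other two compounds also have only limits, so the three cannot be ranked against one another.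

The change in compound 4 `CN(C)c1c([N+](=O)[O-])cc(/C=C/c2ccc3ccccc3c2)cc1[N+](=O)[O-]` is dimethylamino in place of methoxy on an aromatic carbon and it falls on an aromatic carbon ortho to two nitro groups. Going by the values given here, two measured steps bear on this only loosely, a step that the two limits leave unreadable from compound 1 to compound 2 for nitro in place of methoxy and a step that the two limits leave unreadable from compound 2 to compound 3 for a change in double-bond configuration. Neither has a readable size, so neither offers a size or direction to carry over. The expected step that the limit leaves unreadable from compound 2 to compound 4 therefore has no firm direction, and no change beyond the scatter is expected in this assay on this evidence. For compound 4 the estimate is 8000 nM with an expected range from 2000 nM to 20000 nM and the result may well be only a limit too.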

Compound 4, half-maximal inhibitory concentration: > 5000 nM
Compound 4 gave a limit, no number; the forecaster's own chance of this, stated with the estimate: 65%; the middle value does not contradict the limit.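

Compound 2 and compound 4 both give only limits, so the step from methoxy to dimethylamino cannot be read. The compounds shown leave open how strongly any of them inhibits in this assay, and whether any of these changes shifts that at all.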